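The source may report more compounds than this note shows. Statements on the series, on what has been measured and on what is new or still open speak of the compounds shown alone.

In a functional assay on FM3A cells (Mus musculus) for cytotoxicity, read by cell counting, with a stated time of 2 days (on this read-out higher numbers stand for weaker inhibition and lower numbers for stronger inhibition), compound 1 `C=C(Br)C(=O)Nc1ccc(/C=C2\SC(=O)N(Cc3cccc(F)c3)C2=O)cc1` gives 4000 nM and compound 2 `C=C(Br)C(=O)Nc1ccc(/C=C2\SC(=O)N(Cc3ccc(F)cc3)C2=O)cc1` gives 4600 nM. Within the data shown here, the single measured step, a 1.2-fold higher number from compound 1 to compound 2 (0.06 log units; within the scatter), leaves the number essentially where it was. Of the two numbers shown, compound 2 carries the larger, yet its distance from compound 1 lies within the scatter. Compound 3 `C=C(Br)C(=O)Nc1ccc(/C=C2\SC(=O)N(Cc3ccc(C(C)(C)C)cc3)C2=O)cc1` differs from compound 2 by tert-butyl in place of fluoro on an aromatic carbon. Among the measured compounds shown here, no measured step replaces fluoro with tert-butyl, so the one step at hand bears only loosely on this change. The number for compound 3 is therefore expected to stay close to that of compound 2, with a 1.0-fold lower number from compound 2 to compound 3 (0.01 log units; within the scatter) as the expected step. Compound 3 is estimated at 4500 nM, between 1500 nM and 14000 nM.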

Compound 3, half-maximal inhibitory concentration: 4000 nM
For compound 3 the middle estimate is 1.1-fold (0.05 log units) above the measured one, and the stated range covers the measured number.
By their numbers in this assay, from the lowest: compounds 1, 3 and 2 (each within the scatter of the next).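

Placing tert-butyl on this aromatic carbon adds heavy atoms to the fluoro position, yet this assay gives a 1.2-fold lower number from compound 2 to compound 3 (0.06 log units; within the scatter), so the group's larger size leaves the number within the scatter here. The comparison no change at the digits printed from compound 1 to compound 3 (within the scatter) also places 4-(tert-butyl)phenyl level with 3-fluorophenyl. No supporting measurement accounts for this result.

Going by these compounds, whether an amine or a carboxylic acid on this aromatic carbon would keep the number in the same range remains open. So does the outcome with a longer chain on the ring nitrogen of the shared core.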